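The source may report more compounds than this note shows. Statements on the series, on what has been measured and on what is new or still open speak of the compounds shown alone.

Measured in an ADME assay on microsomes (Rattus norvegicus) for pharmacokinetics; on this read-out higher numbers stand for fast clearance and lower numbers for slow clearance:

- compound 1 `CCNc1nc(Nc2ccc3c(c2)NC(=O)COC3(C)C)nc2ccoc12`: 318 mL/min/kg
- compound 2 `CCCNc1nc(Nc2ccc3c(c2)NC(=O)COC3(C)C)nc2ccoc12`: 373 mL/min/kg
- compound 3 `CC(C)CNc1nc(Nc2ccc3c(c2)NC(=O)COC3(C)C)nc2ccoc12`: 1080 mL/min/kg

Compound 3 has the highest number of the three. The gaps to the others lie beyond the scatter: a 3.4-fold higher number from compound 1 to compound 3 (0.53 log units; beyond the scatter) and a 2.9-fold higher number from compound 2 to compound 3 (0.46 log units; beyond the scatter). Both steps are modest. The remaining step, a 1.2-fold higher number from compound 1 to compound 2 (0.07 log units; within the scatter), lies within the scatter.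

Next in line is compound 4 `CC1(C)OCC(=O)Nc2cc(Nc3nc(NC4CC4)c4occc4n3)ccc21`, which keeps the shared core and changes only the group on the amine: cyclopropyl in place of isobutyl on a nitrogen on an aromatic ring. In words, cyclopropyl in place of isobutyl on a nitrogen on an aromatic ring.

Among the measured compounds shown here, no measured compound carries a ring at this place, so the evidence is indirect. The closest guide is the pair of steps that lead to compound 3, a 3.4-fold higher number from compound 1 to compound 3 (0.53 log units; beyond the scatter) and a 2.9-fold higher number from compound 2 to compound 3 (0.46 log units; beyond the scatter), which suggest that leaving isobutyl could bring a modest fall in this assay. The expected change is therefore of similar size and downward, and it is estimated as a 3.1-fold lower number from compound 3 to compound 4 (0.49 log units; beyond the scatter). From the compounds shown here alone, this would place the new compound close to the unbranched pair, though the ring itself remains untested. For compound 4 the estimated value is 350 mL/min/kg, with an expected range of 150 mL/min/kg to 800 mL/min/kg.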

Compound 4, clearance: 200 mL/min/kg
The estimate for compound 4 lay 1.8-fold (0.24 log units) above the measured number; measured number inside the range.
By their numbers in this assay, from the lowest: compounds 4, 1 and 2 (each within the scatter of the next); then compound 3.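

In this assay, among the compounds shown here, the nitrogen on an aromatic ring now carries a ring for the first time, and cyclopropyl in place of isobutyl gives a 5.4-fold lower number from compound 3 to compound 4 (0.73 log units; beyond the scatter) on the clearance read-out. Compared with the unbranched chains, cyclopropyl cannot be told apart from propyl or ethyl, with a 1.9-fold lower number from compound 2 to compound 4 (0.27 log units; within the scatter) and a 1.6-fold lower number from compound 1 to compound 4 (0.20 log units; within the scatter) as the two steps, so among these four compounds only compound 3, with isobutyl, stands apart, while the small ring, ethyl and propyl form one group within the scatter. No measurement available here bears on why isobutyl differs from the other three groups at this place.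

The compounds shown leave open whether the high number of compound 3 belongs to isobutyl alone or would recur with other larger groups on this nitrogen, such as cyclobutyl, cyclopentyl or a longer unbranched chain like butyl. They also leave open what a hydroxyl or an ether oxygen on the chain would do, since every group seen so far at this place is built of carbon only.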